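The source may hold more compounds than are shown below. What is called first, only, known or untested is meant among the compounds shown, and "the series" means these compounds.

Of the compounds shown here, three built on one shared core have been measured in an assay on HEK293 cells for inhibition of Voltage-dependent T-type calcium channel subunit alpha-1G (Homo sapiens), read by fluorescence, tested at 10 uM; on this read-out lower numbers stand for less inhibition and higher numbers for more inhibition at the one concentration tested (going by the name of the read-out). Compound 1 `CCCc1nc(-c2ccccc2)c(CNCCN2CCN(c3ccccc3OC)CC2)o1` gives 39.7%. For the measured compounds named here, compound 2 `CCCc1nc(-c2ccccc2)c(CNCCN2CCN(c3ccccc3Cl)CC2)o1` gives 60.1%, and the one single-point step among the measured compounds is a number 20.4 percentage points higher from compound 1 to compound 2 (beyond the scatter). Compound 3 `CCCc1nc(-c2ccccc2)c(CNCCCN2CCN(c3cccc(F)c3)CC2)o1` gives 68.9%, the highest of the three numbers; its gap to compound 2 is within the scatter, while its gap to compound 1 is beyond it.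

Compound 4 `CCCc1nc(-c2ccccc2)c(CNCCCN2CCN(c3cccc(C)c3C)CC2)o1` has not yet been measured. It differs from compound 3 in one place: 2,3-dimethylphenyl in place of 3-fluorophenyl on an amine nitrogen in a ring. Going by the values given here, no measured step exchanges the group on the amine nitrogen in a ring in this way; the only step known, chloro in place of methoxy on an aromatic carbon, is a different exchange and was modest in size, so it bears on compound 4 only loosely. Compound 4 is therefore expected to stay close to compound 3, with an estimated step of a number 3.9 percentage points lower from compound 3 to compound 4 (within the scatter), within the usual scatter. The estimate for compound 4 is 65%, expected to fall between 45% and 85%.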

Compound 4, a percentage reported as inhibition, at one concentration (the size of the read-out at that concentration, not a potency): 55.2%
For compound 4 the middle estimate is 9.8 percentage points above the measured one, and the stated range covers the measured number.
By their numbers in this assay, from the lowest: compound 1; then compounds 4, 2 and 3 (each within the scatter of the next, the first and the last beyond it).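

Exchanging the group on the amine nitrogen in the ring is not a neutral change in this assay: 2,3-dimethylphenyl in place of 3-fluorophenyl gives a number 13.7 percentage points lower from compound 3 to compound 4 (beyond the scatter) and so lies beyond the scatter. The entering and leaving groups both hold one six-membered aromatic ring of carbon only and neither carries hydrogen-bond donors or acceptors, so the step arises with those counts unchanged. Nothing available explains this step. The compounds shown do not separate the loss of the fluoro group from the gain of the two methyl groups, which a plain phenyl or a 3-methylphenyl group on the same nitrogen would begin to do. They also leave open whether a chloro group on the phenyl ring would hold the number of compound 3 on this chain.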